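Pyrimidine series: ring amine to branched alkyl at the core

A few compounds are considered here, and "the series" means these few. Any claim that something is new, unique, unknown or untested is made for them only; others in the source may bear on it.

Working notes on a small set of compounds measured in an assay on isolated protein for binding affinity to corticotropin-releasing factor receptor 1 (Homo sapiens); a higher number here means a weaker inhibitor, a lower number a stronger inhibitor. Compound 1 `CCN(c1nc(C)cc(N2CCCCC2)n1)c1ccc(C(C)C)cc1Br` gives 29 nM and stands highest of the three numbers shown. Compound 2 `CCN(CC)c1cc(C)nc(N(CC)c2ccc(C(C)=O)cc2Br)n1` gives 5 nM and compound 3 `CCCCN(CC#N)c1nc(C)nc(N(CC)c2ccc(N(C)C)cc2C(F)(F)F)n1` gives 6 nM; both lie below compound 1 by a gap beyond the usual scatter, and the two of them are within the scatter of each other, so no order between them is claimed. Within the data shown here, nothing in the set connects these three to one another by a single change, and no measured step covers the change considered next.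

Compound 4 `CCC(CC)c1cc(C)nc(N(CC)c2ccc(C(C)C)cc2Br)n1` differs from compound 1 in one place: pentan-3-yl in place of piperidin-1-yl on an aromatic carbon. The change keeps the rest of compound 1 intact. Among the measured compounds shown here, with no measured step of this kind, the expectation is a small move, either none beyond the scatter or a modest fall in the number, and it rests only on compound 1 giving 29 nM. The estimated step from compound 1 to compound 4 is a 1.5-fold lower number from compound 1 to compound 4 (0.16 log units; within the scatter). Compound 4 is therefore expected to give about 20 nM, within a range from 6 nM to 60 nM.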

Compound 4, inhibition constant: 2 nM
For compound 4 the middle estimate is 10-fold (1.00 log units) above the measured one; measured number below the stated range.
By their numbers in this assay, from the lowest: compound 4; then compounds 2 and 3 (each within the scatter of the next); then compound 1.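

In this assay, the group on this aromatic carbon next to the ring nitrogen has a large bearing on the number: pentan-3-yl in place of piperidin-1-yl gives a 15-fold lower number from compound 1 to compound 4 (1.16 log units; beyond the scatter). With the rest of compound 1 unchanged, neither the six-membered ring nor its nitrogen is required at this place, since an open branched alkyl with no ring and no hydrogen-bond acceptor serves there. No measurement at hand accounts for the size of this step.

The step removes the ring and the nitrogen together, so it leaves open which of the two carries the difference. Cyclohexyl would keep the ring without the nitrogen and dipropylamino would keep the nitrogen without the ring, and how either stands against compound 4 remains open.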